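The source may report more compounds than this note shows. Statements on the series, on what has been measured and on what is new or still open speak of the compounds shown alone.

In an ADME assay on Caco-2 cells (Homo sapiens) for permeability, read by LC-MS, in the apical to basolateral direction, with a stated time of 60 min, at pH 6.5 (a higher number here means that the compound crosses the layer faster, a lower number that the compound crosses the layer more slowly), three compounds have been measured:

Compound 1 `CC(C)(C)OC[C@@H](O)C(=O)N1[C@H](C(=O)NCc2cc(Cl)ccc2-n2cnnn2)C[C@@H]2C[C@@H]21`: 4.5 10^-6 cm/s
Compound 2 `O=C(NCc1cc(Cl)ccc1-n1cnnn1)[C@@H]1CCNN1C(=O)[C@H](O)c1ccccc1`: 5.3 10^-6 cm/s
Compound 3 `CC(C)(C)[C@@H](O)C(=O)N1CC(=O)C[C@H]1C(=O)NCc1cc(Cl)ccc1-n1cnnn1`: 0.8 10^-6 cm/s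

Compound 1 at 4.5 10^-6 cm/s cannot be told apart from compound 2 at 5.3 10^-6 cm/s, as the gap between them lies within the usual scatter. Compound 3 at 0.8 10^-6 cm/s gives a clearly lower number than compound 1, and that gap lies beyond the scatter.

The next compound to be measured is compound 4 `COC(C)(C)[C@@H](O)C(=O)N1[C@H](C(=O)NCc2cc(Cl)ccc2-n2cnnn2)C[C@@H]2C[C@@H]21`. It keeps the core of compound 1 but carries 1-methoxy-1-methylethyl in place of (tert-butoxy)methyl on a saturated chain carbon bound to a carbonyl carbon and an oxygen on a saturated carbon.

For the measured compounds named here, no two measured compounds differ in only one place, so the data contain no measured step to serve as a guide. Neither group has a ring or a net charge, and the estimate therefore starts from compound 1 at 4.5 10^-6 cm/s. In this assay, the expected step of a 1.1-fold lower number from compound 1 to compound 4 (0.05 log units; within the scatter) is none beyond the scatter, with no firm direction. The estimated value for compound 4 is 4 10^-6 cm/s, with an expected range of 2 10^-6 cm/s to 8 10^-6 cm/s.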

Compound 4, apparent permeability: 16 10^-6 cm/s
For compound 4 the middle estimate is 4.0-fold (0.60 log units) below the measured one; the measured number lies above the stated range.
By their numbers in this assay, from the lowest: compound 3; then compounds 1 and 2 (each within the scatter of the next); then compound 4.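

For the compounds shown here, until now no two measured compounds differed in only one place, so nothing showed how much this position on a saturated chain carbon bound to a carbonyl carbon and an oxygen on a saturated carbon matters in this assay. Replacing (tert-butoxy)methyl with 1-methoxy-1-methylethyl gives a 3.6-fold higher number from compound 1 to compound 4 (0.55 log units; beyond the scatter) on an unchanged core, even though neither group has a ring or a net charge, both have the same hydrogen-bond donor and acceptor counts, and the entering group has 5 heavy atoms in place of 6. This single pair therefore shows that a change this small in the counts can still move the number beyond the scatter, but no measurement at hand accounts for the step.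

The swap rearranges the whole group at once, so the compounds shown cannot separate the placement of the oxygen from the branching of the chain. They also leave open how a 2-methoxyethyl group or an amine would behave at this position on the core of compound 1.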